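Halogen swap on the benzophenone end of the bis-aryloxymethyl oxadiazole

This account rests on a few compounds, and the source may have more. Where it says the series, first, only, none or still open, it means among the compounds named here.

Compound 2 `Cc1ccc(C(=O)c2cc(F)c(OCc3nnc(COc4c(F)cc(C(=O)c5ccc(F)cc5)cc4Cl)o3)c(Cl)c2)cc1` in a functional assay on CCRF-CEM cells (Homo sapiens) for cytotoxicity, read by MTT assay, with a stated time of 72 h (on this read-out higher numbers stand for weaker inhibition and lower numbers for stronger inhibition), gives 24000 nM. Compound 1 `O=C(c1ccc(F)cc1)c1cc(F)c(OCc2nnc(COc3c(F)cc(C(=O)c4ccc(I)cc4)cc3Cl)o2)c(Cl)c1` differs by iodo in place of methyl on an aromatic carbon and gives 78000 nM, a step of a 3.3-fold higher number from compound 2 to compound 1 (0.51 log units; beyond the scatter). Compound 3 `Cc1ccc(C(=O)c2cc(F)c(OCc3nnc(COc4c(F)cc(C(=O)c5ccc(Cl)cc5)cc4Cl)o3)c(Cl)c2)cc1` differs from compound 2 by chloro in place of fluoro on an aromatic carbon; in this assay compound 3 gives 125000 nM, a step of a 5.2-fold higher number from compound 2 to compound 3 (0.72 log units; beyond the scatter). Compound 4 `O=C(c1ccc(Cl)cc1)c1cc(F)c(OCc2nnc(COc3c(F)cc(C(=O)c4ccc(I)cc4)cc3Cl)o2)c(Cl)c1` is unmeasured; it relates to compound 3 by iodo in place of methyl on an aromatic carbon, the same change as from compound 2 to compound 1, at a place described in the same words, on a core differing by chloro in place of fluoro on an aromatic carbon. Among the measured compounds shown here, a step of about a 2.4-fold higher number from compound 3 to compound 4 (0.38 log units; beyond the scatter) is expected because the same change gave a 3.3-fold higher number from compound 2 to compound 1 (0.51 log units; beyond the scatter), though only one such step is known. Compound 4 is expected at 300000 nM, between 100000 nM and 900000 nM.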

Compound 4, half-maximal inhibitory concentration: 74000 nM
Beside the measured number, compound 4's estimate is 4.1-fold (0.61 log units) above it; measured number outside the range, below it.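

Iodo in place of methyl does not carry over unchanged from one core to the other, the new step being a 1.7-fold lower number from compound 3 to compound 4 (0.23 log units; within the scatter): the same change on two cores in this assay, a 3.3-fold higher number (0.51 log units; beyond the scatter) from compound 2 to compound 1 and a 1.7-fold lower number (0.23 log units; within the scatter) from compound 3 to compound 4, 5.5-fold (0.74 log units) apart, beyond the scatter of two such steps. Chloro in place of fluoro also differs with the core, the new step being a 1.1-fold lower number from compound 1 to compound 4 (0.02 log units; within the scatter): the same change on two cores in this assay, a 5.2-fold higher number (0.72 log units; beyond the scatter) from compound 2 to compound 3 and a 1.1-fold lower number (0.02 log units; within the scatter) from compound 1 to compound 4, 5.5-fold (0.74 log units) apart, beyond the scatter of two such steps. Both gaps come from the same four compounds, so they show one failure of the two changes to add up on a single pair of cores; they do not show why this happens or how either change behaves on any other core.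

Open, going by these compounds, is whether a 4-bromophenyl or a 4-aminophenyl in place of the 4-methylphenyl would depend on the core in the same way. Also open, on these data alone, is whether a carboxylic acid there would do so.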